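The source may report more compounds than this note shows. Statements on the series, on what has been measured and on what is new or still open speak of the compounds shown alone.

Measured in a functional assay on DU-145 cells (Homo sapiens) for inhibition, read by trypan blue exclusion, with a stated time of 96 h; on this read-out lower numbers stand for stronger inhibition of growth and higher numbers for weaker inhibition of growth:
- Compound 1 `COc1ccc(C(=O)/C(=C\c2ccc(OC)c(O)c2)Sc2ccc(F)cc2)cc1`: 1000 nM
- Compound 2 `COc1ccc(C(=O)/C(=C\c2ccc(Br)cc2)Sc2ccc(F)cc2)cc1`: > 100000 nM, a limit
- Compound 3 `COc1ccc(C(=O)/C(=C\c2ccc(Cl)cc2)Sc2ccc(F)cc2)cc1`: > 100000 nM, a limit

Compound 3 gives no number in this assay, only the limit > 100000 nM. It shares this position with compound 2, as seen in the limit of > 100000 nM in this assay, at which 2 of the 3 values shown sit.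

Compound 4 `COc1ccc(/C=C(/Sc2ccc(F)cc2)C(=O)c2ccc(OC)cc2)cc1` has methoxy in place of chloro on an aromatic carbon, para to a large group: methoxy in place of chloro on an aromatic carbon. For the measured compounds named here, no measured step makes this exact exchange. The closest evidence is an at least 100-fold higher number from compound 1 to compound 3 (2.00 log units; beyond the scatter), together with an at least 100-fold higher number from compound 1 to compound 2 (2.00 log units; beyond the scatter). Both are large and beyond the scatter, and both alter the same aryl position. By contrast, a step that the two limits leave unreadable from compound 2 to compound 3 gives no size.

Compound 1, at 1000 nM, shows that a number can be reached with a different aryl group there, so a moderate move toward stronger inhibition is expected. Even so, compound 4 may well stay at the limit. The expected step is an at least 3.3-fold lower number from compound 3 to compound 4 (0.52 log units; beyond the scatter). For compound 4 the estimate is 30000 nM, with an expected range from 3000 nM to 100000 nM.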

Compound 4, concentration for 50% growth inhibition: 25000 nM
Estimate against measurement, compound 4: 1.2-fold (0.08 log units) above, and the stated range covers the measured number.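

In this assay, the 4-methoxyphenyl group gives a readable number at this position, where the 4-bromophenyl and 4-chlorophenyl groups did not: an at least 4.0-fold lower number from compound 3 to compound 4 (0.60 log units; beyond the scatter) and an at least 4.0-fold lower number from compound 2 to compound 4 (0.60 log units; beyond the scatter). Both steps are minimum sizes, as compound 2 and compound 3 are each held at a limit of the assay: the limit of > 100000 nM in this assay, at which 2 of the 4 values shown sit. The methoxy group alone does not match compound 1, however, and with hydrogen in place of hydroxy the data show a 25-fold higher number from compound 1 to compound 4 (1.40 log units; beyond the scatter), so that single hydroxy group separates the two compounds by a large margin.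

The step between compound 2 and compound 3 cannot be read, so the bromo and chloro compounds remain unranked. Going by these compounds, whether an amine or a carboxylic acid on the same aromatic carbon would give a readable number stays open.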